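A few compounds are considered here, and "the series" means these few. Any claim that something is new, unique, unknown or untested is made for them only; others in the source may bear on it.

Measured so far:
- compound 1, `COc1ccc(-c2cc(/C=C/C(=O)c3ccc(N)cc3)[nH]n2)cc1`, -10%
- compound 2, `COc1cc(-c2cc(/C=C/C(=O)c3ccc(Cl)c(Cl)c3)[nH]n2)cc(OC)c1OC`, 53%

Among the measured compounds shown here, in a functional assay on HT-29 cells (Homo sapiens) for cytotoxicity, read by sulforhodamine B assay, with a stated time of 48 h, tested at 10 uM (a higher number here means a weaker effect of the compound at the concentration tested, a lower number a stronger effect), compound 2 gives 53%, the highest of the two numbers so far; its nearest neighbour is compound 1, which in this assay gives -10%, a number lower by a margin beyond the scatter. For the measured compounds named here, the two compounds differ in more than one place, so no single step between them is counted; their values only show that the series spans a wide range at this concentration.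

Compound 3, `COc1ccc(C(=O)/C=C/c2cc(-c3cc(OC)c(OC)c(OC)c3)n[nH]2)cc1`, is the next compound for this assay. Relative to compound 2 the change is 4-methoxyphenyl in place of 3,4-dichlorophenyl on a carbonyl carbon.

Going by the values given here, no step between measured compounds is available for this change. For compound 3 a step downward from compound 2 in this assay is expected, of size a number 18 percentage points lower from compound 2 to compound 3 (beyond the scatter), though a result within the scatter is also possible. The estimate for compound 3 in this assay is 35%, within -5% to 75%.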

Compound 3, a percentage reported as activity, at one concentration (the size of the read-out at that concentration, not a potency): -58%
Compound 3: middle estimate off by 93 percentage points, on the high side; the measured number lies below the stated range.
By their numbers in this assay, from the lowest: compound 3; then compound 1; then compound 2.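

In this assay, among the compounds shown here, the change to 4-methoxyphenyl in place of 3,4-dichlorophenyl on a carbonyl carbon gives a number 111 percentage points lower from compound 2 to compound 3 (beyond the scatter) and so provides the first one-place comparison. With the rest of the structure held constant, the group on this carbonyl carbon is enough on its own to produce a large shift in the read-out. Nothing available explains the step, and the counted differences do not show whether the chlorine atoms, the methoxy oxygen or the substitution as a whole matters.

Going by these compounds, whether a single chlorine, an unsubstituted phenyl or a phenyl bearing a carboxylic acid would fall nearer compound 2 or compound 3 remains open. On these data alone, it is also open whether the same change gives a similar step on the core of compound 1.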